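This account rests on a few compounds, and the source may have more. Where it says the series, first, only, none or still open, it means among the compounds named here.

Among the measured compounds shown here, compound 2 `Fc1ccc(OCc2cc(OCC(F)(F)F)nc(-c3ccccn3)n2)c(F)c1F` is the stronger of the two compounds measured so far in a functional assay on cells for antagonist activity at Free fatty acid receptor 1 (Homo sapiens), read by TR-FRET and inositol phosphate accumulation, with a stated time of 2 h; a higher number here means a weaker inhibitor, a lower number a stronger inhibitor: compound 2 gives 7.94 nM, whereas compound 1 `OC1CN(c2cc(COc3ccc(F)c(F)c3F)nc(-c3ccccn3)n2)C1` gives 3160 nM, and the step of a 400-fold lower number from compound 1 to compound 2 (2.60 log units; beyond the scatter) is the only measured step in the set. Compound 3 `Fc1ccc(OCc2cc(OCC3COC3)nc(-c3ccccn3)n2)c(F)c1F` has not yet been measured. It differs from compound 2 by a single change, (oxetan-3-yl in place of trifluoromethyl on a saturated chain carbon bound to an oxygen on an aromatic ring). For the measured compounds named here, no measured step addresses exactly this exchange; the one step that bears on it at all, from compound 1 to compound 2, shows that the group at the other position on the shared core can move the number by a great deal, and that of the two groups tried there, the 2,2,2-trifluoroethoxy gave the far lower number. On that basis, compound 3 is expected to lose some potency, an estimated step of a 13-fold higher number from compound 2 to compound 3 (1.10 log units; beyond the scatter) in this assay. The estimate for compound 3 is 100 nM, with a range from 15 nM to 700 nM.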

Compound 3, half-maximal inhibitory concentration: 316 nM
The estimate for compound 3 lay 3.2-fold (0.50 log units) below the measured number; the measured number falls inside the stated range.
By their numbers in this assay, from the lowest: compound 2; then compound 3; then compound 1.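

In this assay the group on the saturated chain carbon bound to an oxygen on an aromatic ring matters in its own right: oxetan-3-yl in place of trifluoromethyl, with the same count of heavy atoms, gives a 40-fold higher number from compound 2 to compound 3 (1.60 log units; beyond the scatter) and so costs much of the strength of compound 2. Among the compounds shown here, the earlier compounds showed only that exchanging the whole group on the aromatic carbon moves the number, whereas this change leaves the oxygen on the aromatic ring in place. The (oxetan-3-yl)methoxy group still keeps a 10-fold lower number from compound 1 to compound 3 (1.00 log units; beyond the scatter) as its gain over 3-hydroxyazetidin-1-yl, which places it between the other two groups on this carbon. From the compounds shown here alone, whether a plain methyl, a cyclopropyl or a longer fluorinated chain would bring the number back towards that of compound 2 remains open, as does the effect of an amine here. Nothing at hand bears on the reason for these steps.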